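Methyl to methoxy on two pyrazole-based cores

A few compounds are considered here, and "the series" means these few. Any claim that something is new, unique, unknown or untested is made for them only; others in the source may bear on it.

Measured so far in a functional assay on the whole organism (strain Wistar albino) for inhibition, with Rattus norvegicus as the target, read by paw edema, with stated times of 1 h and 3 h, at a dose of 0.32 mmol/kg by the intraperitoneal route; a lower number here means less inhibition, a higher number more inhibition at the dose given (going by the name of the read-out):
compound 1 `COc1ccc(C(=O)C(CC(=O)c2ccc(Cl)cc2)c2cn(-c3ccc(S(N)(=O)=O)cc3)nc2-c2ccc(C)cc2)cc1`, 61.1%
compound 2 `COc1ccc(C(=O)C(CC(=O)c2ccc(Cl)cc2)c2cn(-c3ccc(S(N)(=O)=O)cc3)nc2-c2ccc(OC)cc2)cc1`, 22.5%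
compound 3 `Cc1ccc(-c2nn(-c3ccc(Cl)cc3)cc2-c2cc(-c3ccc(Cl)cc3)[nH]c2-c2ccc(F)cc2)cc1`, 21%

Compound 2 carries one change against compound 1, (methoxy in place of methyl on an aromatic carbon), and this step, a number 38.6 percentage points lower from compound 1 to compound 2 (beyond the scatter), is the only one measured. Compound 3 stands on a different core; the difference between the two cores is not broken down here. Its value lies within the scatter of compound 2, so no order between these two is claimed.

Compound 4 `COc1ccc(-c2nn(-c3ccc(Cl)cc3)cc2-c2cc(-c3ccc(Cl)cc3)[nH]c2-c2ccc(F)cc2)cc1` is compound 3 with the same change, (methoxy in place of methyl on an aromatic carbon), at the same kind of place. On this basis a downward step is expected, but compound 3 starts low because 21% leaves little room, so the expected step of a number 8 percentage points lower from compound 3 to compound 4 (within the scatter) is estimated smaller than the measured one. Compound 4 is expected at 13%, within 2% to 30%.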

Compound 4, a percentage reported as inhibition, in the whole organism at one dose (the size of the read-out at that dose, not a potency): 61.9%
Compound 4: the middle estimate sits 48.9 percentage points below what was measured; measured number outside the range, above it.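

In this assay, the change from 4-methylphenyl to 4-methoxyphenyl gives a number 40.9 percentage points higher from compound 3 to compound 4 (beyond the scatter), so a step measured on one core does not predict even the direction of the step on the other: the same change on two cores in this assay, a number 38.6 percentage points lower (beyond the scatter) from compound 1 to compound 2 and a number 40.9 percentage points higher (beyond the scatter) from compound 3 to compound 4, 79.5 percentage points apart, beyond the scatter of two such steps. The result rests on one pair per core and shows only that the outcome of this change depends on the core in these two pairs. It does not show which structural difference between the cores decides the direction, and a reading at one dose is not a potency.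

Still open, on these data alone, is how a hydroxyl, an amine or a longer chain such as ethoxy at this place would read on each core.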